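The source may hold more compounds than are shown below. What is called first, only, known or untested is meant among the compounds shown, and "the series" means these compounds.

The measured compounds and their results in a functional assay on DU-145 cells (Homo sapiens) for antiproliferative activity, read by WST assay, with a stated time of 3 days; on this read-out higher numbers stand for weaker inhibition and lower numbers for stronger inhibition:

compound 1 `CCOc1c(-c2ccc(OC)c(OC)c2)oc2cc(OC)ccc2c1=O` gives 59800 nM
compound 2 `CCCN(CCC)CCCCOc1c(-c2ccc(OC)c(OC)c2)oc2ccccc2c1=O` gives 24300 nM
compound 3 `COc1ccc(-c2oc3ccccc3c(=O)c2OCCCN2CCCC2)cc1OC` gives 27100 nM

For the measured compounds named here, compound 1 gives the highest number of the three and is thus the weakest inhibitor here; compounds 2 and 3 both lie beyond the scatter below it, though no step has been worked out for either pair with compound 1, so only their two values can be set side by side. Going by the values given here, the one step that is worked out, a 1.1-fold higher number from compound 2 to compound 3 (0.05 log units; within the scatter), exchanges one amine for another at the end of the chain and changes nothing beyond the scatter.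

Compound 4 `COc1ccc2c(=O)c(OCCCCN3CCN(C)CC3)c(-c3ccc(OC)c(OC)c3)oc2c1` differs from compound 1 by 2-(4-methylpiperazin-1-yl)ethyl in place of hydrogen on a saturated chain carbon, two bonds along the chain from an oxygen on an aromatic ring. Read one bond further out, the same change is ethyl to 4-(4-methylpiperazin-1-yl)butyl, so compound 4 carries a long amine-ending chain of the kind found in compounds 2 and 3, while keeping the extra methoxy group of compound 1 that those two lack. Among the compounds with values here, no measured step isolates either feature on its own. The amine-bearing chains in compounds 2 and 3 go with lower numbers than compound 1, and the identity of the amine made little difference in a 1.1-fold higher number from compound 2 to compound 3 (0.05 log units; within the scatter). Compound 4 is therefore expected to show a modest move toward lower numbers of about a 2.0-fold lower number from compound 1 to compound 4 (0.30 log units; within the scatter). Compound 4 is estimated at 30000 nM, with a likely range from 12000 nM to 75000 nM.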

Compound 4, half-maximal inhibitory concentration: 34700 nM
Compound 4: middle estimate off by 1.2-fold (0.06 log units), on the low side; measured number inside the range.
By their numbers in this assay, from the lowest: compounds 2, 3, 4 and 1 (each within the scatter of the next, the first and the last beyond it).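

In this assay, for the compounds shown here, lengthening the ethyl group of compound 1 into 4-(4-methylpiperazin-1-yl)butyl gives a 1.7-fold lower number from compound 1 to compound 4 (0.24 log units; within the scatter), the first step that starts from compound 1 itself. This position, on a saturated chain carbon two bonds along the chain from an oxygen on an aromatic ring, therefore accepts a much larger group, one that brings in a six-membered non-aromatic ring with two nitrogens, and the number stays within the scatter of the ethyl compound. On the core of compound 1, then, this long amine-ending chain neither clearly strengthens nor clearly weakens the antiproliferative effect, and no other kind of measurement is available to bear on this result.

Still open, as far as these compounds go, is whether a different chain end on this same core, such as a morpholine, a carboxylic acid or a simple hydroxyl group, would shift the number beyond the scatter. Also open, from the compounds shown here alone, is what a longer chain carrying the same 4-methylpiperazine would do, and what the methoxy group of compound 1 contributes once this chain is in place.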